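The source may report more compounds than this note shows. Statements on the series, on what has been measured and on what is new or still open speak of the compounds shown alone.

In a functional assay on HL-60 cells (Homo sapiens) for cytotoxicity, read by MTT assay, with a stated time of 72 h (on this read-out higher numbers stand for weaker inhibition and lower numbers for stronger inhibition), compound 1 `COC(=O)c1sc2cc(OC)ccc2c1Nc1cc(OC)c(OC)c(OC)c1` gives 0.4 nM. Compound 2 `CCOC(=O)c1sc2c(OC)c(C)c(C)c(C)c2c1Nc1cc(OC)c(OC)c(OC)c1` gives 25.6 nM, and compound 3 `COC(=O)c1sc2cc(C)ccc2c1Nc1cc(OC)c(OC)c(OC)c1` gives 20.5 nM. Compound 3 thus stands second highest of the three numbers, within the scatter of compound 2 yet far from compound 1, the step being a 51-fold higher number from compound 1 to compound 3 (1.71 log units; beyond the scatter). Compound 4 `COC(=O)c1sc2ccccc2c1Nc1cc(OC)c(OC)c(OC)c1` differs from compound 3 by hydrogen in place of methyl on an aromatic carbon. Going by the values given here, no measured step removes this group outright; the only step touching the same place is the exchange of methoxy for methyl, and that one was large. Whether a hydrogen here ends up nearer compound 3 or nearer compound 1 cannot be read from these three, so a moderate step toward lower numbers is expected, a 2.6-fold lower number from compound 3 to compound 4 (0.41 log units; beyond the scatter). Compound 4 is therefore estimated at 8 nM, within 1.5 nM to 40 nM.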

Compound 4, half-maximal inhibitory concentration: 1540 nM
Estimate against measurement, compound 4: 190-fold (2.28 log units) below, and the stated range ends below it.
By their numbers in this assay, from the lowest: compound 1; then compounds 3 and 2 (each within the scatter of the next); then compound 4.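

Hydrogen in place of methyl gives a 75-fold higher number from compound 3 to compound 4 (1.88 log units; beyond the scatter) and hydrogen in place of methoxy gives a 3900-fold higher number from compound 1 to compound 4 (3.59 log units; beyond the scatter) in this assay. Among the three compounds that differ only on this aromatic carbon, the bare position therefore gives the highest number, and even a single methyl carbon there lowers it sharply. Methoxy lowers it much further, so this position is far more sensitive than the earlier compounds could show.

As far as these compounds go, whether an amine, a chlorine or a longer chain such as ethoxy would match methoxy here remains open. Nothing shown explains why this position responds so strongly.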